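Replacing the Ring on the Amine Nitrogen of Compound 2

A few compounds are considered here, and "the series" means these few. Any claim that something is new, unique, unknown or untested is made for them only; others in the source may bear on it.

Compound 1, `Brc1ccc(C2=NN(C3=NC(c4ccccc4)CS3)C(c3ccc4ccccc4c3)C2)cc1`, gives 4960 nM in a functional assay on HeLa cells (Homo sapiens) for inhibition, read by CCK-8 assay, with a stated time of 48 h; on this read-out lower numbers stand for stronger inhibition and higher numbers for weaker inhibition.
Compound 2, `O=C1CSC(N2N=C(c3ccc(Br)cc3)CC2c2cccc3ccccc23)=N1`, gives 5810 nM in this assay.
Compound 3, `COc1ccc(C2=NN(C3=NC(=O)CS3)C(c3cccc4ccccc34)C2)cc1`, gives 2540 nM in this assay.

Compound 2 stands highest of the three numbers in this assay; compound 1 lies within the scatter of it, while compound 3 is set apart by a 2.3-fold lower number from compound 2 to compound 3 (0.36 log units; beyond the scatter). That one measured step concerns a methoxy in place of bromo and does not bear on the change at hand. Compound 4, `Brc1ccc(C2=NN(C3=NC(c4ccccc4)CS3)C(c3cccc4ccccc34)C2)cc1`, differs from compound 2 by a group of 11 heavy atoms (9 carbon, 1 nitrogen, 1 sulfur; one five-membered non-aromatic ring with 2 hetero atoms, one six-membered aromatic ring of carbon only) in place of a group of 6 heavy atoms (3 carbon, 1 nitrogen, 1 oxygen, 1 sulfur; one five-membered non-aromatic ring with 2 hetero atoms), on an amine nitrogen in a ring. For the measured compounds named here, no measured step isolates this change; compound 1 carries the entering group but differs from compound 2 in two places, and the values of compound 1 and compound 2 lie within the scatter of each other. Compound 4 is therefore expected to show a 1.2-fold lower number from compound 2 to compound 4 (0.07 log units; within the scatter), nothing beyond the scatter. The estimate for compound 4 in this assay is 5000 nM, expected between 2000 nM and 12000 nM.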

Compound 4, half-maximal inhibitory concentration: 6650 nM
The estimate for compound 4 lay 1.3-fold (0.12 log units) below the measured number; the measured number falls inside the stated range.
By their numbers in this assay, from the lowest: compounds 3, 1, 2 and 4 (each within the scatter of the next, the first and the last beyond it).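

In this assay, the exchange on the amine nitrogen in a ring now has a step of its own (a 1.1-fold higher number from compound 2 to compound 4 (0.06 log units; within the scatter)), so the larger group with its added six-membered aromatic ring leaves the number within the scatter. Naphthalen-1-yl in place of naphthalen-2-yl on a saturated ring carbon also stays within the scatter (a 1.3-fold higher number from compound 1 to compound 4 (0.13 log units; within the scatter)). No measurement shown explains these results. The compounds shown leave open whether a carboxylic acid or an amine on that added aromatic ring would shift the number beyond the scatter.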